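Swapping 4-methoxyphenyl for naphthalen-2-yl in a shared core

The compounds below may be only part of what the source reports. "The series", "measured", "known", "first", "only" and "open" are said of these compounds alone.

In a functional assay on BGC-823 cells (Homo sapiens) for inhibition, read by MTT assay, with a stated time of 72 h (a lower number here means a stronger inhibitor, a higher number a weaker inhibitor), compound 1 (`Cc1ccc(CN2CCc3ncn(COCc4ccccc4)c3/C(=C/c3ccccc3)C2=O)cc1`) gives 39100 nM and compound 2 (`O=C1/C(=C\c2ccccc2)c2c(ncn2COCc2ccccc2)CCN1Cc1ccc(-c2ccccc2)cc1`) gives 81000 nM while compound 3 (`COc1ccc(CN2CCc3ncn(COCc4ccccc4)c3/C(=C/c3ccccc3)C2=O)cc1`) gives 71600 nM as its value. Compound 3 lies within the scatter of both the others, and the only gap beyond the scatter is a 2.1-fold higher number from compound 1 to compound 2 (0.32 log units; beyond the scatter) and that step is modest.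

Compound 4 (`O=C1/C(=C\c2ccccc2)c2c(ncn2COCc2ccccc2)CCN1Cc1ccc2ccccc2c1`) has naphthalen-2-yl in place of 4-methoxyphenyl on a saturated chain carbon bound to an amide-type nitrogen in a ring. Going by the values given here, no measured step makes this exact swap. The closest steps alter the same aromatic group: a 1.1-fold lower number from compound 2 to compound 3 (0.05 log units; within the scatter) and a 1.8-fold higher number from compound 1 to compound 3 (0.26 log units; within the scatter) both stay within the scatter. Compound 2 also ends in an all-carbon aromatic group and gives 81000 nM so no step beyond the scatter is expected for compound 4 in this assay here.

The expected change is a 1.2-fold lower number from compound 3 to compound 4 (0.06 log units; within the scatter) and stays within the scatter. Compound 4 is estimated at 62000 nM with an expected range from 30000 nM to 115000 nM as its bounds.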

Compound 4, half-maximal inhibitory concentration: 93300 nM
Compound 4: the middle estimate sits 1.5-fold (0.18 log units) below what was measured; the range from low to high includes it.
By their numbers in this assay, from the lowest: compounds 1, 3, 2 and 4 (each within the scatter of the next, the first and the last beyond it).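

In this assay, naphthalen-2-yl on a saturated chain carbon bound to an amide-type nitrogen in a ring cannot be told apart from 4-methoxyphenyl, with a 1.3-fold higher number from compound 3 to compound 4 (0.11 log units; within the scatter), or from the 4-phenylphenyl of compound 2, with a 1.2-fold higher number from compound 2 to compound 4 (0.06 log units; within the scatter). So this position accepts a group with two fused aromatic rings and no oxygen, and the number stays level with those of the two earlier compounds. The only gap beyond the scatter is modest, at a 2.4-fold higher number from compound 1 to compound 4 (0.38 log units; beyond the scatter); 4-methylphenyl now stands apart from both all-carbon groups in compound 2 and compound 4, though not from the 4-methoxyphenyl of compound 3.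

Every group shown at this position is aromatic, so what an amine, a carboxylic acid or a longer chain would do here stays open. Nothing available explains even these small gaps.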